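Methyl in place of bromo on an arylmethylamine MAO-B inhibitor

This account rests on a few compounds, and the source may have more. Where it says the series, first, only, none or still open, it means among the compounds named here.

Compound 1 `C#CCNC1CCc2c(NCc3ccccc3)cccc21`: > 20000 nM in an assay on cells for inhibition of Amine oxidase [flavin-containing] B (Homo sapiens), read by fluorescence and Amplex Red, with stated times of 30 min and 15 min; on this read-out lower numbers stand for stronger inhibition and higher numbers for weaker inhibition
Compound 2 `C#CCNC1CCc2c(NCc3cccc(Br)c3)cccc21`: 110 nM in this assay

Compound 1 gives only a limit of the assay, not a number. Compound 2 gives the only number shown, and it is the stronger inhibitor of the two; the step from compound 1 to compound 2 is an at least 180-fold lower number from compound 1 to compound 2 (2.25 log units; beyond the scatter). Compound 3 `C#CCNC1CCc2c(NCc3cccc(C)c3)cccc21` keeps the whole core of compound 2 and differs in one place: methyl in place of bromo on an aromatic carbon.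

Among the measured compounds shown here, only the step from compound 1 to compound 2 bears on this change, and it shows that a group on this aromatic carbon, rather than hydrogen, makes a very large difference. Methyl also fills that position, so compound 3 is expected to keep much of the inhibition of compound 2, while a somewhat higher number seems more likely than a lower one. The expected step from compound 2 to compound 3 is a 3.6-fold higher number from compound 2 to compound 3 (0.56 log units; beyond the scatter). Compound 3 is therefore estimated at 400 nM, with a range from 100 nM to 2000 nM.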

Compound 3, half-maximal inhibitory concentration: 710 nM
Compound 3: middle estimate off by 1.8-fold (0.25 log units), on the low side, within the range that was stated.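

In this assay the two groups are not interchangeable at this position, since the swap gives a 6.5-fold higher number from compound 2 to compound 3 (0.81 log units; beyond the scatter) and the comparison here favours bromo. Methyl in place of hydrogen still gives an at least 28-fold lower number from compound 1 to compound 3 (1.44 log units; beyond the scatter) and so the large gain seen with bromo does not depend on bromo alone. The size of that gain can be stated only as a minimum, because compound 1 stands at a limit of the assay and not at a number: the limit of > 20000 nM in this assay, at which 1 of the 3 values shown sits.

With only hydrogen, methyl and bromo at this position, the compounds shown leave open how groups such as chloro, methoxy or an amine would behave there. They also leave open whether bromo and methyl would differ in the same way elsewhere on this ring.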